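This account rests on a few compounds, and the source may have more. Where it says the series, first, only, none or still open, it means among the compounds named here.

Compound 1 `O=C(c1ccc(Cl)c(C(F)(F)F)c1)N1CCC(n2cncc2-c2ccc(OS(=O)(=O)c3cccc4cnccc34)cc2)CC1`: 22 nM
Compound 2 `O=C(c1ccc([N+](=O)[O-])cc1)N1CCC(n2cncc2-c2ccc(OS(=O)(=O)c3cccc4cnccc34)cc2)CC1`: 8.29 nM
Compound 3 `CN(C)c1ccc(C(=O)N2CCC(n3cncc3-c3ccc(OS(=O)(=O)c4cccc5cnccc45)cc3)CC2)cc1`: 2.19 nM

Of the compounds shown here, three sharing one core have been measured in an assay on THP-1 cells for antagonist activity at P2X purinoceptor 7 (Homo sapiens), read by ELISA, with a stated time of 30 min; on this read-out lower numbers stand for stronger inhibition and higher numbers for weaker inhibition. They differ only in the group attached to the carbonyl carbon of the amide. Compound 3 gives the lowest number of the three; the step of a 3.8-fold lower number from compound 2 to compound 3 (0.58 log units; beyond the scatter) and the step of a 10-fold lower number from compound 1 to compound 3 (1.00 log units; beyond the scatter) both lie beyond the scatter, so compound 3 stands apart as the strongest of the measured set.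

Compound 4 `CC(C)c1ccc(C(=O)N2CCC(n3cncc3-c3ccc(OS(=O)(=O)c4cccc5cnccc45)cc3)CC2)cc1` is the next variation. Compared with compound 3, the change is isopropyl in place of dimethylamino on an aromatic carbon. Among the measured compounds shown here, no measured step concerns the isopropyl group, so the existing steps bear on it only indirectly: the steps of a 2.7-fold lower number from compound 1 to compound 2 (0.42 log units; beyond the scatter), a 10-fold lower number from compound 1 to compound 3 (1.00 log units; beyond the scatter) and a 3.8-fold lower number from compound 2 to compound 3 (0.58 log units; beyond the scatter) show that the group on this carbon moves the number by modest amounts, and that the dimethylamino of compound 3 gives the lowest number so far. Replacing it is expected to shift the number upward by a modest step, a 3.7-fold higher number from compound 3 to compound 4 (0.56 log units; beyond the scatter), perhaps toward the number of compound 2.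

Compound 4 is therefore estimated at 8 nM, with a likely range from 3 nM to 25 nM.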

Compound 4, half-maximal inhibitory concentration: 37 nM
Estimate against measurement, compound 4: 4.6-fold (0.67 log units) below; measured number outside the range, above it.
By their numbers in this assay, from the lowest: compound 3; then compound 2; then compounds 1 and 4 (each within the scatter of the next).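

Dimethylamino and isopropyl have the same count of heavy atoms, yet exchanging the nitrogen for a carbon, and with it losing the one hydrogen-bond acceptor, gives a 17-fold higher number from compound 3 to compound 4 (1.23 log units; beyond the scatter) in this assay, so the number at this position does not follow the heavy-atom count alone. Isopropyl also compares poorly with nitro, with a 4.5-fold higher number from compound 2 to compound 4 (0.65 log units; beyond the scatter), so among the compounds with a single group on this carbon, the two groups containing nitrogen give lower numbers than the one made only of carbon and hydrogen, while a 1.7-fold higher number from compound 1 to compound 4 (0.23 log units; within the scatter) means that compound 4 and compound 1 cannot be told apart. Nothing available explains why this exchange matters so much.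

The compounds shown leave open whether it is the nitrogen itself that counts, which a plain amino group or a methoxy group on the same carbon could help to test. They also leave open how a longer chain, such as diethylamino, would compare with the dimethylamino of compound 3.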